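The compounds below may be only part of what the source reports. "The series", "measured", "known", "first", "only" and "open" are said of these compounds alone.

Compound 1 `COc1ccc(F)cc1CNCCCNc1ccnc2cc(Oc3ccc(C(C)(C)C)cc3)ccc12` is one of three compounds that share a core and were tested in a physicochemical assay for solubility, with a stated time of 18 h, at pH 7.4; a lower number here means a less soluble compound, a higher number a more soluble compound. In that assay compound 1 gives 14500 nM, level with compound 2 `CC(C)(C)c1ccc(Oc2ccc3c(NCCCNCc4ccco4)ccnc3c2)cc1`, which gives 14500 nM; together these are the highest of the three numbers. Compound 3 `c1coc(CNCCCNc2ccnc3cc(CC4CCCCC4)ccc23)c1` gives 4200 nM, a number that stands below compound 1 by more than the scatter. Among the compounds with values here, the only step between measured compounds that differ in one place is no change at the digits printed from compound 1 to compound 2 (within the scatter), and it concerns the saturated chain carbon bound to an amine nitrogen, not the aromatic carbon changed here. Compound 4 `COc1ccc(-c2ccc3c(NCCCNCc4cc(F)ccc4OC)ccnc3c2)cc1` has not yet been measured in this assay. It differs from compound 1 as follows: 4-methoxyphenyl in place of 4-(tert-butyl)phenoxy on an aromatic carbon. Within the data shown here, no measured step touches this aromatic carbon, so the direction of the change rests on the general picture that the three numbers give rather than on a directly comparable pair. Among the measured compounds shown here, compound 2 and compound 3 differ at this same region of the core, and their values show a lower number for compound 3, but no step between them is established here. On that footing compound 4 is expected to sit near compound 1, with the step of a 1.5-fold higher number from compound 1 to compound 4 (0.18 log units; within the scatter) estimated to stay within or only slightly beyond the scatter. The estimate for compound 4 in this assay is 22000 nM, in a range from 7000 nM to 70000 nM.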

Compound 4, solubility: 32000 nM
Compound 4: middle estimate off by 1.5-fold (0.16 log units), on the low side; low and high end bracket the measured number.
By their numbers in this assay, from the lowest: compound 3; then compounds 1 and 2 (each within the scatter of the next); then compound 4.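

Within the data shown here, at this aromatic carbon, where no step had been measured before, this assay shows a 2.2-fold higher number from compound 1 to compound 4 (0.34 log units; beyond the scatter) and so a modest change that lies beyond the scatter. The only earlier step, no change at the digits printed from compound 1 to compound 2 (within the scatter) on a saturated chain carbon, stayed within the scatter, which makes this aromatic carbon the one place among the steps shown where a single change moves the number beyond it. The 4-methoxyphenyl that enters and the 4-(tert-butyl)phenoxy that leaves have the same counts of aromatic rings, hydrogen-bond donors and hydrogen-bond acceptors, differing in that the entering group has fewer heavy atoms than the leaving group, and nothing measured here accounts for the higher number.

The step swaps the whole group at once, so the compounds shown do not separate the contribution of the tert-butyl from that of the methoxy, or that of the phenoxy oxygen from a direct link to the aromatic ring. They also leave open whether a smaller group at this aromatic carbon, such as an unsubstituted phenyl, or a different one, such as a morpholine or a carboxylic acid, would continue the same direction or reverse it.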